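A few compounds are considered here, and "the series" means these few. Any claim that something is new, unique, unknown or untested is made for them only; others in the source may bear on it.

In an ADME assay on HepG2 2.2.15 cells (Homo sapiens) for cytotoxicity, read by CCK-8 assay, with a stated time of 8 days (a lower number here means that less compound is tolerated, a higher number that more compound is tolerated), compound 1 `COc1ccc(-c2cc(NC(=O)c3ccccc3O)c[nH]c2=O)cc1` gives > 100000 nM. That value is a limit of the assay, not a number. Going by the values given here, compound 2 `CCOc1ccc(-c2cc(NC(=O)c3ccccc3O)c[nH]c2=O)cc1` gives 41000 nM, the only true number so far. Compound 3 `CCOc1ccc(-c2cc(NC(=O)c3cc(OC)ccc3O)c[nH]c2=O)cc1` differs from compound 2 at one place: methoxy in place of hydrogen on an aromatic carbon. A methoxy replaces hydrogen on an aromatic carbon, para to a hydroxy group. Among the compounds with values here, only one measured step can guide the expectation, an at least 2.4-fold lower number from compound 1 to compound 2 (0.38 log units; beyond the scatter), and it was made elsewhere in the molecule, on the saturated chain carbon bound to an oxygen. It shows that a small addition can shift this read-out beyond the scatter, but it says little about the new site. A small move towards a lower number is therefore expected, and it may not exceed the scatter. The expected change is a 1.2-fold lower number from compound 2 to compound 3 (0.07 log units; within the scatter). For compound 3 the estimated value is 35000 nM, with an expected range of 13000 nM to 100000 nM.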

Compound 3, half-maximal cytotoxic concentration: 57700 nM
For compound 3 the middle estimate is 1.6-fold (0.22 log units) below the measured one; the range from low to high includes it.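

In this assay, a methoxy on this aromatic carbon, para to a hydroxy group, gives a 1.4-fold higher number from compound 2 to compound 3 (0.15 log units; within the scatter), so the swap from 2-hydroxyphenyl to 2-hydroxy-5-methoxyphenyl cannot be told apart from repeat-measurement noise. The earlier step, on the saturated chain carbon bound to an oxygen, lay beyond the scatter, so the two sites do not respond alike to these small additions, at least for this pair of changes. This is also the first step here between two true numbers, since the earlier one starts from a value that is only a limit: the limit of > 100000 nM in this assay, at which 1 of the 3 values shown sits.

Going by these compounds, whether this carbon would tolerate a quite different group, such as an amine or a carboxylic acid, stays open. So does whether a methoxy on another carbon of this ring would leave the read-out equally undisturbed.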